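The source may hold more compounds than are shown below. What is called first, only, known or untested is meant among the compounds shown, and "the series" means these compounds.

Compound 1 `Cc1cc(NC(=O)c2cc([N+](=O)[O-])ccc2Cl)cc(-c2nc3ccccc3s2)c1O`: 430 nM
Compound 2 `O=C(Nc1cc(-c2nc3ccccc3s2)ccc1Cl)c1cc([N+](=O)[O-])ccc1Cl`: 100 nM

In a physicochemical assay for solubility, read by spectrophotometry, in phosphate buffer, measured as kinetic solubility, with a stated time of 18 h, at pH 7.4 (on this read-out higher numbers stand for higher solubility and lower numbers for lower solubility), compound 1 holds the higher of the two numbers, and compound 2 gives 100 nM, a gap beyond the scatter. Compound 3 `O=C(Nc1ccc(O)c(-c2nc3ccccc3s2)c1)c1cc([N+](=O)[O-])ccc1Cl` is the next compound, not yet measured. It differs from compound 1 in one place: hydrogen in place of methyl on an aromatic carbon. Among the measured compounds shown here, with no step between measured compounds to lean on, only a small change is expected here, likely none beyond the scatter, with the step from compound 1 to compound 3 estimated at a 1.2-fold higher number from compound 1 to compound 3 (0.07 log units; within the scatter). Compound 3 is expected to give about 500 nM, within 200 nM to 1300 nM.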

Compound 3, solubility: 23 nM
Estimate against measurement, compound 3: 22-fold (1.34 log units) above; the measured number lies below the stated range.
By their numbers in this assay, from the lowest: compound 3; then compound 2; then compound 1.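

Replacing the methyl with hydrogen on the aromatic carbon ortho to a hydroxy group removes only one heavy atom, yet in this assay it gives a 19-fold lower number from compound 1 to compound 3 (1.27 log units; beyond the scatter). This position is therefore far from silent: a very small edit here goes with a large change in the read-out. Nothing measured here bears on the reason for this step.

The compounds shown hold only methyl and hydrogen at this position. Going by these compounds, what an ethyl group, a methoxy group or an amine would give there remains open.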